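This account rests on a few compounds, and the source may have more. Where it says the series, first, only, none or still open, it means among the compounds named here.

Series notes, step from compound 2 to compound 4.

The three measured compounds share one core and differ only in the amine on the chain carbon bound to the carbonyl. Compound 1 `CN(C)CC(=O)N1CCC(NS(=O)(=O)c2cc(S(=O)(=O)c3ccccc3)ccc2C(F)(F)F)CC1` gives 300 nM in an assay on isolated protein for binding affinity to secreted frizzled-related protein 1 (Homo sapiens), read by fluorescence; on this read-out higher numbers stand for weaker inhibition and lower numbers for stronger inhibition. Compound 2 `O=C(CN1CCCC1)N1CCC(NS(=O)(=O)c2cc(S(=O)(=O)c3ccccc3)ccc2C(F)(F)F)CC1` gives 110 nM in this assay, and compound 3 `O=C(CN1CCNCC1)N1CCC(NS(=O)(=O)c2cc(S(=O)(=O)c3ccccc3)ccc2C(F)(F)F)CC1` gives 140 nM. Compound 2 has the lowest number of the three: the steps of a 2.7-fold lower number from compound 1 to compound 2 (0.44 log units; beyond the scatter) and a 2.1-fold lower number from compound 1 to compound 3 (0.33 log units; beyond the scatter) are both modest, while a 1.3-fold higher number from compound 2 to compound 3 (0.10 log units; within the scatter) leaves compound 2 and compound 3 within the scatter of each other.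

Compound 4 `CC(C)(C)OC(=O)N1CCC[C@@H]1C(=O)N1CCC(NS(=O)(=O)c2cc(S(=O)(=O)c3ccccc3)ccc2C(F)(F)F)CC1` is not yet measured. It differs from compound 2 by 1-(tert-butoxycarbonyl)pyrrolidin-2-yl in place of (pyrrolidin-1-yl)methyl on a carbonyl carbon. Among the compounds with values here, none of the measured steps tests a change at the carbonyl carbon itself; the measured steps only exchange one amine for another on the chain carbon, and those exchanges move the number by modest amounts. The change to compound 4 is larger in what leaves and what enters, so the expectation rests on little. Within the data shown here, a small rise in the number is expected for a 2.3-fold higher number from compound 2 to compound 4 (0.36 log units; beyond the scatter), with the wide range reflecting that no comparable step has been measured. Compound 4 is therefore estimated at 250 nM in this assay, between 70 nM and 900 nM.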

Compound 4, half-maximal inhibitory concentration: 120 nM
Compound 4: middle estimate off by 2.1-fold (0.32 log units), on the high side, and the stated range covers the measured number.
By their numbers in this assay, from the lowest: compounds 2, 4 and 3 (each within the scatter of the next); then compound 1.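

In this assay, the carbonyl carbon accepts a much larger change than the earlier amine exchanges tested: 1-(tert-butoxycarbonyl)pyrrolidin-2-yl in place of (pyrrolidin-1-yl)methyl gives a 1.1-fold higher number from compound 2 to compound 4 (0.04 log units; within the scatter), and in place of (piperazin-1-yl)methyl it gives a 1.2-fold lower number from compound 3 to compound 4 (0.07 log units; within the scatter). Among compound 2, compound 3 and compound 4, an amine nitrogen on a chain carbon bound to the carbonyl is therefore not required to keep the number in this range, since compound 4 carries its ring directly on the carbonyl carbon and has tert-butoxycarbonyl on the ring nitrogen. The modest step in this set remains the one from the dimethylamino compound, a 2.5-fold lower number from compound 1 to compound 4 (0.40 log units; beyond the scatter), and nothing shown accounts for why the number holds across so large a replacement.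

Open, from the compounds shown here alone, is how the number responds when tert-butoxycarbonyl is removed to leave the free pyrrolidin-2-yl amine, and when the defined stereocentre has the opposite configuration. Also open, going by these compounds, is whether a carboxylic acid on the pyrrolidine ring or a longer chain bearing the amine on the carbonyl carbon would hold the number in the same range.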